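From 4-methylphenyl to 2-nitrophenyl on the shared core

The source may report more compounds than this note shows. Statements on the series, on what has been measured and on what is new or still open speak of the compounds shown alone.

For the measured compounds named here, in a functional assay on K562/A02 cells (Homo sapiens) for antiproliferative activity, read by MTT assay (a lower number here means a stronger inhibitor, a higher number a weaker inhibitor), compound 1 `O=C(CCCCCNC(=S)NN=C(c1ccccc1)c1ccccc1)NO` gives 3640 nM and compound 2 `Cc1ccc(/C(=N/NC(=S)NCCCCCC(=O)NO)c2ccccc2)cc1` gives 3150 nM so the two stand level on the numbers so far. Compound 3 `O=C(CCCCCNC(=S)N/N=C(\c1ccccc1)c1ccccc1[N+](=O)[O-])NO` departs from compound 2 by 2-nitrophenyl in place of 4-methylphenyl on a carbon with a double bond to nitrogen as a change of one group. In words, 2-nitrophenyl takes the place of 4-methylphenyl on a carbon with a double bond to nitrogen. Going by the values given here, only one measured step bears on this: methyl in place of hydrogen on an aromatic carbon, seen as a 1.2-fold lower number from compound 1 to compound 2 (0.06 log units; within the scatter) in the only pair available. Among the compounds with values here, that step is small, but no measured compound carries 2-nitrophenyl, so the guide is thin. No step beyond the scatter is expected, and the estimate is a 1.1-fold higher number from compound 2 to compound 3 (0.05 log units; within the scatter) with a wide margin. In this assay compound 3 is estimated at 3500 nM within an expected range of 1500 nM to 8000 nM overall.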

Compound 3, half-maximal inhibitory concentration: 1310 nM
Compound 3: the middle estimate sits 2.7-fold (0.43 log units) above what was measured; measured number below the stated range.
By their numbers in this assay, from the lowest: compound 3; then compounds 2 and 1 (each within the scatter of the next).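

In this assay the aromatic ring on the carbon with a double bond to nitrogen no longer looks silent: methyl in place of hydrogen left the number within the scatter, whereas nitro in place of hydrogen gives a modest gain (a 2.8-fold lower number from compound 1 to compound 3 (0.44 log units; beyond the scatter)). Replacing 4-methylphenyl with 2-nitrophenyl gives a step of similar size (a 2.4-fold lower number from compound 2 to compound 3 (0.38 log units; beyond the scatter)), so compound 3 stands clear of both earlier compounds, while compound 2 shows that a new group on this ring does not by itself shift the number. Nothing available accounts for this gain.

The names 4-methylphenyl and 2-nitrophenyl differ in both the group and its number, so these compounds cannot separate the two. As far as these compounds go, whether an amine or a chlorine on this ring would match nitro also remains open.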